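One More Methyl on a Chain at the Limit

The compounds below may be only part of what the source reports. "The series", "measured", "known", "first", "only" and "open" are said of these compounds alone.

- Compound 1 `CCOc1c(-c2cc(OC)c(OC)c(OC)c2)oc2ccccc2c1=O`: 6200 nM
- Compound 2 `CCCOc1c(-c2cc(OC)c(OC)c(OC)c2)oc2ccccc2c1=O`: 2800 nM
- Compound 3 `CCCCOc1c(-c2cc(OC)c(OC)c(OC)c2)oc2ccccc2c1=O`: > 50000 nM

All three compounds share one core and differ only in the chain on its oxygen. In a functional assay on DU-145 cells (Homo sapiens) for antiproliferative activity, read by WST assay, with a stated time of 3 days (on this read-out higher numbers stand for weaker inhibition and lower numbers for stronger inhibition), compound 3 gives > 50000 nM, which is a limit of the assay and not a number.

Compound 4 `CCCCCOc1c(-c2cc(OC)c(OC)c(OC)c2)oc2ccccc2c1=O` carries a longer chain, with methyl in place of hydrogen at its end: methyl in place of hydrogen on a saturated chain carbon, four bonds along the chain from an oxygen on an aromatic ring.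

Among the measured compounds shown here, three measured steps bear on this change. Lengthening the chain first gave a modest gain, a 2.2-fold lower number from compound 1 to compound 2 (0.35 log units; beyond the scatter). The next lengthening gave a large loss, an at least 17-fold higher number from compound 2 to compound 3 (1.25 log units; beyond the scatter). Overall, the chain change shows an at least 8.0-fold higher number from compound 1 to compound 3 (0.90 log units; beyond the scatter). On these data alone, the steps therefore do not run in one direction, and the last one ends at a limit, so its true size is unknown.

In this assay no step beyond the scatter is expected, and compound 4 should remain weak, quite possibly at the same limit. The expected step is a number no higher from compound 3 to compound 4 (the limit leaves the size open). For compound 4 the estimated value is 50000 nM, with an expected range of 12000 nM to 150000 nM.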

Compound 4, half-maximal inhibitory concentration: > 50000 nM
Compound 4: a limit, no number; the forecaster's own chance of this, stated with the estimate: 65%; the middle value sits exactly at the limit.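

In this assay compound 4 gives > 50000 nM, which is a limit of the assay and not a number. Adding one more methyl at the chain end does not bring back the activity of the shorter chains, and the loss first seen with compound 3 persists, with an at least 17-fold higher number from compound 2 to compound 4 (1.25 log units; beyond the scatter) and an at least 8.0-fold higher number from compound 1 to compound 4 (0.90 log units; beyond the scatter). Compound 3 and compound 4 both sit at this limit, so the step between them cannot be read: the limit of > 50000 nM in this assay, at which 2 of the 4 values shown sit.

On these data alone, how far beyond the limit either compound lies remains open, and so does whether the longer chain changes anything at all. As far as these compounds go, it is also open whether an amine or a carboxylic acid at the end of a chain of this length would restore a measurable value in this assay.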